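A Morpholine Swap on a Long-Lived Scaffold

This account rests on a few compounds, and the source may have more. Where it says the series, first, only, none or still open, it means among the compounds named here.

Three compounds sharing one core have been followed in an ADME assay on the whole organism (lung, Rattus norvegicus) for metabolic stability, read by LC-MS; on this read-out lower numbers stand for a shorter-lived compound and higher numbers for a longer-lived compound. Compound 1 `Cc1csc2cc([C@H](C)Nc3ncnc(N)c3C#N)c(-c3cccc(CN(C)CCCCN(C)Cc4ccccc4)c3)c(=O)n12` gives 17.6 h in this assay. Compound 2 `Cc1csc2cc([C@H](C)Nc3ncnc(N)c3C#N)c(-c3cccc(CN4CCC(CN(C)CC(C)C)CC4)c3)c(=O)n12` gives 12 h in this assay, a number that sits within the usual scatter of that for compound 1, so the two cannot be told apart on this read-out. Compound 3 `Cc1csc2cc([C@H](C)Nc3ncnc(N)c3C#N)c(Cc3cccc(CN4CCC4)c3)c(=O)n12`, which carries a different linker and a smaller amine, gives 1.1 h in this assay, a number far below that of compound 1 and well beyond the scatter. Compound 1 thus stands at the long-lived end of what has been measured, together with compound 2.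

Compound 4 `Cc1csc2cc([C@H](C)Nc3ncnc(N)c3C#N)c(-c3cccc(CN(C)CCCN4C[C@@H](C)O[C@@H](C)C4)c3)c(=O)n12` has not yet been measured. It differs from compound 1 in one place: 2,6-dimethylmorpholin-4-yl in place of (benzyl(methyl)amino)methyl on a saturated chain carbon, three bonds along the chain from an amine nitrogen. The chain and the amine nitrogen nearest the aromatic ring are kept; only the group at the far end of the chain is exchanged.

For the measured compounds named here, no measured pair in this set isolates this particular exchange, so the size of its effect is open. Both compounds keep the same tail length and the same kind of attachment, and on that basis a step within the scatter is expected, with no clear direction, so the estimated step from compound 1 to compound 4 is a 1.5-fold lower number from compound 1 to compound 4 (0.17 log units; within the scatter). Compound 4 is therefore expected to give about 12 h in this assay, with a range from 5 h to 30 h.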

Compound 4, half-life: 5.9 h
Estimate against measurement, compound 4: 2.0-fold (0.31 log units) above; the range from low to high includes it.
By their numbers in this assay, from the lowest: compound 3; then compound 4; then compounds 2 and 1 (each within the scatter of the next).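

In this assay, putting 2,6-dimethylmorpholin-4-yl in place of (benzyl(methyl)amino)methyl on a saturated chain carbon, three bonds along the chain from an amine nitrogen, gives a 3.0-fold lower number from compound 1 to compound 4 (0.47 log units; beyond the scatter), a modest step but one beyond the usual scatter. For the compounds shown here, the earlier compounds differed from one another in more than one place, so this is the first comparison in which a single exchange can be read, and it shows that the group at the far end of the chain can shift this read-out even when the nitrogen nearest the aromatic ring stays in place. Nothing in the data shown explains why the number falls.

The exchange alters several things at once: a six-membered aromatic ring of carbon leaves, while a non-aromatic ring with an oxygen and two defined stereocentres enters, so the compounds shown cannot say which of these changes carries the step. Plain morpholin-4-yl without the two methyl groups, or piperidin-1-yl with no ring oxygen, at this same place would begin to pull those changes apart.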